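Chloro in place of hydrogen at the assay limit

The compounds below may be only part of what the source reports. "The series", "measured", "known", "first", "only" and "open" are said of these compounds alone.

In a functional assay on NCI/ADR-RES cells (Homo sapiens) for inhibition, read by sulforhodamine B assay, with a stated time of 48 h (a higher number here means a weaker inhibitor of growth, a lower number a stronger inhibitor of growth), compound 1 (`Cc1nnc(-c2nn(-c3ccccc3)c(-c3ccccc3)c2C#N)c2cn(-c3ccccc3)nc12`) gives > 100000 nM, a limit and not a number. Compound 2 (`N#Cc1c(-c2nnc(O)c3nn(-c4ccc(Cl)cc4)cc23)nn(-c2ccccc2)c1-c1ccccc1`), which carries a 4-chlorophenyl group, gives > 100000 nM, also a limit. Compound 3 (`N#Cc1c(-c2nnc(-c3ccccc3)c3nn(-c4ccccc4)cc23)nn(-c2ccccc2)c1-c1ccccc1`) gives > 100000 nM, again a limit, so it has no numerical standing in the series. All the data so far are described by the limit of > 100000 nM in this assay, at which 3 of the 3 values shown sit.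

Compound 4 (`N#Cc1c(-c2nnc(-c3ccccc3)c3nn(-c4ccc(Cl)cc4)cc23)nn(-c2ccccc2)c1-c1ccccc1`) differs from compound 3 by chloro in place of hydrogen on an aromatic carbon, para to a large group, turning phenyl to 4-chlorophenyl. For the measured compounds named here, the only measured step is a step that the two limits leave unreadable from compound 1 to compound 3, which supplies no size to carry over. No step beyond the scatter is therefore expected in this assay, and no direction can be assigned. The expected outcome is a number no higher from compound 3 to compound 4 (the limit leaves the size open). For compound 4 the estimate is 100000 nM, with an expected range of 30000 nM to 100000 nM.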

Compound 4, concentration for 50% growth inhibition: 2280 nM
Estimate against measurement, compound 4: 44-fold (1.64 log units) above; measured number below the stated range.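

In this assay, for the compounds shown here, chloro in place of hydrogen on an aromatic carbon, para to a large group, gives the first step of readable size: an at least 43-fold lower number from compound 3 to compound 4 (1.64 log units; beyond the scatter). With the 4-chlorophenyl group kept, exchanging the hydroxy group for a phenyl group gives an at least 43-fold lower number from compound 2 to compound 4 (1.64 log units; beyond the scatter). Among the compounds shown, the 4-chlorophenyl group without the added phenyl and the added phenyl without the chloro both stay at the limit, and a number appears only where the two stand together: the limit of > 100000 nM in this assay, at which 3 of the 4 values shown sit.

Going by these compounds, both steps start from a limit, and their full size stays open. Also open, on these data alone, is whether fluoro, methoxy or an amine in place of the chloro, or a methyl or an amine in place of the added phenyl, would give a number in this assay.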